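The source may report more compounds than this note shows. Statements on the series, on what has been measured and on what is new or still open speak of the compounds shown alone.

Measured compounds:
- compound 1, `N=c1sc2cc(OC(F)(F)F)ccc2n1CC(=O)O`: > 10 mg/kg (a limit)
- compound 2, `CSCn1c(=N)sc2cc(OC(F)(F)F)ccc21`: 3 mg/kg

Compound 1 carries a carboxy group on a saturated chain carbon bound to an aromatic nitrogen. In a functional assay on the whole organism with Rattus norvegicus as the target (on this read-out lower numbers stand for an effect already at smaller amounts and higher numbers for an effect only at larger amounts of compound), compound 1 gives > 10 mg/kg, which is a limit of the assay and not a number. Compound 2 has methylsulfanyl in that place, and in this assay compound 2 gives 3 mg/kg. Among the compounds with values here, the one measured step is an at least 3.3-fold lower number from compound 1 to compound 2 (0.52 log units; beyond the scatter); its size is set by the limit of > 10 mg/kg in this assay, at which 1 of the 2 values shown sits, so only its lower bound is known. Within the data shown here, compound 2 thus holds the only real number in this assay so far.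

Compound 3, `CNCCn1c(=N)sc2cc(OC(F)(F)F)ccc21`, is not yet measured. It differs from compound 2 in one place: (methylamino)methyl in place of methylsulfanyl on a saturated chain carbon bound to an aromatic nitrogen. Among the measured compounds shown here, the measured step concerns carboxy giving way to methylsulfanyl and says nothing about methylsulfanyl giving way to (methylamino)methyl, so no measured step bears directly on this change. The expected step of no change at the digits printed from compound 2 to compound 3 (within the scatter) is therefore one within the scatter, in no particular direction. Compound 3 is estimated to give 3 mg/kg in this assay, with a range from 1 mg/kg to 10 mg/kg.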

Compound 3, dose for half-maximal effect: > 10 mg/kg
Compound 3: only a limit was reported (the forecaster's own chance of this, stated with the estimate: 20%); middle value at least 3.3-fold (0.52 log units) away from the limit.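

On the saturated chain carbon bound to an aromatic nitrogen, (methylamino)methyl in place of methylsulfanyl gives an at least 3.3-fold higher number from compound 2 to compound 3 (0.52 log units; beyond the scatter) in this assay, so the group at this position can shift the dose needed in the whole animal in either direction. Among the three compounds shown, only compound 2, with methylsulfanyl, gives a real number, while the carboxy group of compound 1 and the (methylamino)methyl group of compound 3 both end at the limit of the assay. As far as these compounds go, compound 3 gives > 10 mg/kg, which is a limit and not a number, so the full size of its step remains unknown, and the step from compound 1 to compound 3 cannot be read: the limit of > 10 mg/kg in this assay, at which 2 of the 3 values shown sit.

The change from (methylsulfanyl)methyl to 2-(methylamino)ethyl alters both the chain length and the atom type at once, so the compounds shown cannot separate these two parts of the change. A methoxy group or a dimethylamino group in the same place would be needed to show whether sulfur itself matters or whether the hydrogen on the amine nitrogen goes with the higher number.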